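The compounds below may be only part of what the source reports. "The series", "measured", "known", "first", "only" and "open" are said of these compounds alone.

Measured so far:
- compound 1, `CC(C)(C)c1ccc(C(=O)/C=C/C(=O)O)cc1`, 5100 nM
- compound 2, `O=C(O)/C=C/C(=O)c1ccc(Br)cc1`, 18700 nM

Both were tested in a functional assay on HeLa cells (Homo sapiens) for inhibition, read by MTT assay, with a stated time of 72 h; a lower number here means a stronger inhibitor, a higher number a weaker inhibitor. For the measured compounds named here, compound 2 gives the highest number of the two measured compounds, and the only step known, a 3.7-fold higher number from compound 1 to compound 2 (0.56 log units; beyond the scatter), ties it to compound 1. Compound 3, `O=C(O)/C=C/C(=O)c1ccc(F)cc1`, has not yet been measured; the change from compound 2 is fluoro in place of bromo on an aromatic carbon. Going by the values given here, no measured step swaps one halogen for another, so the one step in hand bears only loosely: it shows that moving from tert-butyl to bromo at this position raised the number modestly. Going further, from bromo to the smaller fluoro, is expected to give at most a small rise in the number, a 1.6-fold higher number from compound 2 to compound 3 (0.21 log units; within the scatter), since nothing in the data points the other way. Compound 3 is estimated at 30000 nM, with a plausible range from 10000 nM to 90000 nM.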

Compound 3, half-maximal inhibitory concentration: 28400 nM
The estimate for compound 3 lay 1.1-fold (0.02 log units) above the measured number; low and high end bracket the measured number.
By their numbers in this assay, from the lowest: compound 1; then compounds 2 and 3 (each within the scatter of the next).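

In this assay, exchanging one halogen for the other on this aromatic carbon gives a 1.5-fold higher number from compound 2 to compound 3 (0.18 log units; within the scatter) and so does not separate bromo from fluoro in this assay. The wider comparison gives a 5.6-fold higher number from compound 1 to compound 3 (0.75 log units; beyond the scatter), so both halogen compounds now stand apart from the tert-butyl compound, and the first step no longer rests on bromo alone. No measurement is available that explains this gap between tert-butyl and the two halogens.

The compounds shown leave open whether the gap belongs to tert-butyl alone, or whether another carbon group at this place, such as methyl or a longer alkyl chain, would also give a number close to that of compound 1. They also leave open where an amine or a methoxy group here would fall relative to these three compounds.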